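Fluoro gives way to ethoxy in compound 3

A few compounds are considered here, and "the series" means these few. Any claim that something is new, unique, unknown or untested is made for them only; others in the source may bear on it.

Measured so far in a functional assay on MCF7 cells (Homo sapiens) for cytotoxicity, read by MTT assay and propidium iodide staining, with a stated time of 24 h; on this read-out lower numbers stand for stronger inhibition and higher numbers for weaker inhibition
- compound 1 `O=C(CSc1nnc(-c2ccncc2)o1)c1ccccc1` with 370 nM as its value
- compound 2 `O=C(CSc1nnc(-c2ccccc2F)o1)c1ccccc1` with 260 nM as its value

Going by the values given here, compound 2 stands within the scatter of compound 1, as the one measured step shows: a 1.4-fold lower number from compound 1 to compound 2 (0.15 log units; within the scatter). Compound 3 `CCOc1ccccc1-c1nnc(SCC(=O)c2ccccc2)o1` brings (ethoxy in place of fluoro on an aromatic carbon), ethoxy in place of fluoro on an aromatic carbon, ortho to a large group. Among the compounds with values here, that measured step swapped a different group, and no measured compound carries ethoxy, so it offers only a weak guide. In this assay, from the compounds shown here alone, no change beyond the scatter is expected, and the direction stays open. The expected size is a 1.2-fold higher number from compound 2 to compound 3 (0.06 log units; within the scatter), an estimate with little behind it. Compound 3 is estimated at 300 nM, with an expected range from 100 nM to 900 nM.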

Compound 3, half-maximal inhibitory concentration: 2670 nM
Estimate against measurement, compound 3: 8.9-fold (0.95 log units) below; the measured number lies above the stated range.
By their numbers in this assay, from the lowest: compounds 2 and 1 (each within the scatter of the next); then compound 3.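

In this assay, this place on the aromatic ring, ortho to a large group, does not take every substituent alike: ethoxy in place of fluoro gives a 10-fold higher number from compound 2 to compound 3 (1.01 log units; beyond the scatter), a large step. The earlier step, which swapped the whole aromatic ring, gave no such sign of sensitivity. Nothing at hand accounts for this weaker result.

From the compounds shown here alone, it stays open whether any group larger than fluoro would do the same, or only ethoxy. Methoxy, an amine or plain hydrogen in this place would help to separate these possibilities.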